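The source may hold more compounds than are shown below. What is called first, only, known or untested is meant among the compounds shown, and "the series" means these compounds.

Working notes on the series in a functional assay on the whole organism (strain Wistar albino) for inhibition, with Rattus norvegicus as the target, read by paw edema, with stated times of 1 h and 2 h, at a dose of 0.32 mmol/kg by the intraperitoneal route; a lower number here means less inhibition, a higher number more inhibition at the dose given (going by the name of the read-out).

Of the compounds shown here, three have numbers so far. Compound 1 `COc1ccc(C(=O)C(CC(=O)c2ccc(Cl)cc2)c2cn(-c3ccc(Cl)cc3)nc2-c2ccc(OC)cc2)cc1` gives 0% in this assay. Compound 2 `COc1ccc(C(=O)C(CC(=O)c2ccc(Cl)cc2)c2cn(-c3ccc(S(N)(=O)=O)cc3)nc2-c2ccc(C)cc2)cc1` gives 53.8% in this assay. Compound 3 `COc1ccc(-c2nn(-c3ccc(S(N)(=O)=O)cc3)cc2C(CC(=O)c2ccc(Cl)cc2)C(=O)c2ccc(F)cc2)cc1` gives 72.2% in this assay, the highest of the three numbers; its nearest neighbour is compound 2, whose number is lower by a gap beyond the scatter, and the furthest is compound 1, lower by a gap far beyond the scatter. Among the compounds with values here, no two measured compounds differ in one place only, so no single step has yet been read, and the three pairs show only their two values each.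

The next compound is compound 4 `COc1ccc(C(=O)C(CC(=O)c2ccc(Cl)cc2)c2cn(-c3ccc(S(N)(=O)=O)cc3)nc2-c2ccc(OC)cc2)cc1`. It differs from compound 3 in one place: methoxy in place of fluoro on an aromatic carbon.

Within the data shown here, with no measured single step to lean on, the expectation rests on the spread of the three numbers. Compound 2 and compound 3 both carry the sulfonamide and sit well above compound 1, and the change here is small, so the expected step in this assay from compound 3 to compound 4 is a number 12.2 percentage points lower from compound 3 to compound 4 (beyond the scatter), a modest move downward that may still fall within the scatter. Compound 4 is therefore estimated at 60%, within a range of 45% to 75%.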

Compound 4, a percentage reported as inhibition, in the whole organism at one dose (the size of the read-out at that dose, not a potency): 30.8%
Compound 4: middle estimate off by 29.2 percentage points, on the high side, outside the stated range (below it).
By their numbers in this assay, from the lowest: compound 1; then compound 4; then compound 2; then compound 3.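

In this assay, the first single-step readings show that the aromatic carbon para to a large group is sensitive to substitution: going from 4-fluorophenyl to 4-methoxyphenyl gives a number 41.4 percentage points lower from compound 3 to compound 4 (beyond the scatter) in a change of only one heavy atom for two, while methoxy in place of methyl on a different aromatic carbon gives a number 23 percentage points lower from compound 2 to compound 4 (beyond the scatter) as a step in the same direction. The sulfamoyl group can now also be read alone, since sulfamoyl in place of chloro on an aromatic carbon gives a number 30.8 percentage points higher from compound 1 to compound 4 (beyond the scatter) with the rest of the structure held constant, a gain that survives even with methoxy on both of the other aromatic rings. No data on hand bear on why these steps take the size and direction they do.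

The compounds shown leave open how the number responds to other groups at the carbon para to a large group, such as chloro, an amine or a longer alkoxy chain, and whether fluoro there keeps its higher number when methyl sits on the other ring. They also leave open whether a carboxylic acid could stand in for the sulfamoyl group.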